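The source may hold more compounds than are shown below. What is called first, only, known or untested is meant among the compounds shown, and "the series" means these compounds.

Compound 1 `NC(=O)c1nccn([C@@H]2O[C@H](CO)[C@@H](O)[C@H]2O)c1=O`: > 250000 nM
Compound 2 `NC(=O)c1nc(F)cnc1O`: > 250000 nM

Both results come from an ADME assay on MDCK cells (Canis lupus familiaris) for cytotoxicity, read by microscopy, with a stated time of 3 days; on this read-out higher numbers stand for lower toxicity in this test and lower numbers for higher toxicity in this test. For compound 1 the result is a limit of the assay rather than a number: in this assay compound 1 gives > 250000 nM. For compound 2 the result is likewise a limit, and in this assay compound 2 gives > 250000 nM. Within the data shown here, both values therefore sit at the limit of > 250000 nM in this assay, at which 2 of the 2 values shown sit, so compound 1 stands at the top of what the assay can report, together with the only other measured compound.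

Compound 3 `NC(=O)c1nc(Br)cn([C@@H]2O[C@H](CO)[C@@H](O)[C@H]2O)c1=O` differs from compound 1 by bromo in place of hydrogen on an aromatic carbon. Among the measured compounds shown here, no step between two measured compounds is available for comparison, so the expected step from compound 1 to compound 3 rests on the two limits alone. The expected step of a number no higher from compound 1 to compound 3 (the limit leaves the size open) is none beyond the scatter in this assay. Compound 3 is estimated at 250000 nM, within 80000 nM to 600000 nM.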

Compound 3, minimum cytotoxic concentration: > 250000 nM
Compound 3: no number, only a limit; the forecaster's own chance of this, stated with the estimate: 80%; the middle value lies on the limit itself.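

In this assay compound 3 gives > 250000 nM as a limit of the assay and not a number. Among these compounds, compound 1 also gives only a limit, so no step between compound 1 and compound 3 can be read: the limit of > 250000 nM in this assay, at which 3 of the 3 values shown sit.

The compounds shown leave open whether bromo in place of hydrogen on an aromatic carbon changes the minimum cytotoxic concentration at all.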